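Chloro in Place of Isopropyl: Expected Inhibition of Compound 4

A few compounds are considered here, and "the series" means these few. Any claim that something is new, unique, unknown or untested is made for them only; others in the source may bear on it.

Compound 1 `Cc1cccc(C(=O)Nc2nn[nH]n2)n1` gives 46% in a functional assay on the whole organism for inhibition, with Rattus norvegicus as the target, at a dose of 3 mg/kg by the oral route; a higher number here means a stronger effect of the compound at the dose given, a lower number a weaker effect.
Compound 2 `O=C(Nc1nn[nH]n1)c1cccc(Br)n1` gives 38% in this assay.
Compound 3 `CC(C)c1ccnc(C(=O)Nc2nn[nH]n2)c1` gives 34% in this assay.

Compound 3 stands lowest of the three numbers; its nearest neighbour is compound 2, whose value lies within the scatter, while compound 1 sits beyond the scatter above it. The unmeasured compound 4 `O=C(Nc1nn[nH]n1)c1cc(Cl)ccn1` differs from compound 3 by chloro in place of isopropyl on an aromatic carbon. For the measured compounds named here, the one measured step that bears on such a swap of an alkyl group for a halogen on an aromatic carbon is a number 8 percentage points lower from compound 1 to compound 2 (within the scatter), which stayed within the scatter. Compound 4 is therefore expected to show a step of a number 4 percentage points lower from compound 3 to compound 4 (within the scatter), not beyond the scatter, in this assay. The estimate for compound 4 is 30%, with a range from 17% to 43%.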

Compound 4, a percentage reported as inhibition, in the whole organism at one dose (the size of the read-out at that dose, not a potency): 72%
For compound 4 the middle estimate is 42 percentage points below the measured one, outside the stated range (above it).
By their numbers in this assay, from the lowest: compounds 3, 2 and 1 (each within the scatter of the next, the first and the last beyond it); then compound 4.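

In this assay, chloro in place of isopropyl on the aromatic carbon opposite the ring nitrogen gave a number 38 percentage points higher from compound 3 to compound 4 (beyond the scatter), so at this position the change has a large effect. For the compounds shown here, the earlier exchange of methyl for bromo, a number 8 percentage points lower from compound 1 to compound 2 (within the scatter), gave no sign of a step of this size. Nothing measured here accounts for the size of this step.

Going by these compounds, whether the gain belongs to chloro alone or would also appear with bromo or fluoro on this carbon remains open. So does the outcome with an amine or a methoxy group there.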